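A few compounds are considered here, and "the series" means these few. Any claim that something is new, unique, unknown or untested is made for them only; others in the source may bear on it.

Compound 1, `COc1ccc(Cl)c(-c2nnc3n2NC(c2ccco2)S3)c1`, and compound 2, `COc1ccc(Cl)c(-c2nnc3n2NC(c2ccc[nH]2)S3)c1`, share one core and differ only in the five-membered ring on the saturated ring carbon. In a functional assay on the whole organism (strain Wistar Albino) for inhibition, with Rattus norvegicus as the target, read by paw edema, with a stated time of 4 h, at a dose of 20 mg/kg (on this read-out higher numbers stand for more inhibition at the one dose given (going by the name of the read-out) and lower numbers for less inhibition), compound 1 gives 25.6%. In this assay, going by the values given here, compound 2 gives 20.6%; it sits at the low end of the two numbers, but the only step it takes part in, a number 5 percentage points lower from compound 1 to compound 2 (within the scatter), is within the scatter, so the two compounds cannot be separated on this read-out.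

Compound 3 is `COc1ccc(Cl)c(-c2nnc3n2NC(c2cccn2C)S3)c1`. It differs from compound 2 by methyl in place of hydrogen on an aromatic nitrogen. Among the compounds with values here, no measured step touches a group on an aromatic nitrogen; the single step known, a number 5 percentage points lower from compound 1 to compound 2 (within the scatter), swaps one five-membered aromatic ring for another and lies within the scatter, so it offers no direction to build on. Compound 3 is therefore expected to show a step of a number 0.4 percentage points higher from compound 2 to compound 3 (within the scatter), nothing beyond the scatter. Compound 3 is estimated at 21%, with a range from 10% to 32%.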

Compound 3, a percentage reported as inhibition, in the whole organism at one dose (the size of the read-out at that dose, not a potency): 20.7%
Beside the measured number, compound 3's estimate is 0.3 percentage points above it; low and high end bracket the measured number.
By their numbers in this assay, from the lowest: compounds 2, 3 and 1 (each within the scatter of the next).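

Going by these compounds alone, this is the first measured step on an aromatic nitrogen: in this assay methyl in place of hydrogen gives a number 0.1 percentage points higher from compound 2 to compound 3 (within the scatter) and so leaves 1H-pyrrol-2-yl and 1-methyl-1H-pyrrol-2-yl inseparable on this read-out. It also adds a second comparison with the furan-2-yl group on the saturated ring carbon: the 1-methyl-1H-pyrrol-2-yl group gives a number 4.9 percentage points lower from compound 1 to compound 3 (within the scatter) and so, like the 1H-pyrrol-2-yl group before it, cannot be told apart from furan-2-yl, which means none of the three groups stands out from the others. Nothing available bears on why these numbers stay so close.

The compounds shown leave open whether a longer chain or a carboxylic acid on that aromatic nitrogen would move the number beyond the scatter, and whether a phenyl ring or an amine in place of the five-membered ring on the saturated ring carbon would do so. They also leave open how the three compounds would compare at other doses and other times, as the read-out gives only one of each.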